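Acetamido Addition on a Sulfonyl Phenyl Ring

The compounds below may be only part of what the source reports. "The series", "measured", "known", "first", "only" and "open" are said of these compounds alone.

Compound 1, `COc1ccc(/C=C2\CN(C)C/C(=C\c3ccncc3)C2=O)c(OC)c1OC`: 3560 nM
Compound 2, `O=C1/C(=C/c2cccnc2)CN(S(=O)(=O)c2ccccc2)C/C1=C\c1ccccc1F`: 8210 nM

In a functional assay on HepG2 cells (Homo sapiens) for cytotoxicity, read by MTT assay, with a stated time of 24 h (on this read-out lower numbers stand for stronger inhibition and higher numbers for weaker inhibition), compound 1 gives 3560 nM, and compound 2 gives 8210 nM. Of these two numbers compound 2 stands highest, and the gap to compound 1 lies beyond the scatter, so compound 2 is the weaker inhibitor of the pair.

Compound 3, `CC(=O)Nc1ccc(S(=O)(=O)N2C/C(=C\c3cccnc3)C(=O)/C(=C/c3ccccc3F)C2)cc1`, differs from compound 2 in one place: acetamido in place of hydrogen on an aromatic carbon. For the measured compounds named here, no two measured compounds differ only in this way, so nothing measured here shows how large such a step is. With no guide, a step in this assay of no more than the scatter is expected, in either direction. For compound 3 the expected value in this assay is 7500 nM, in a range from 3000 nM to 19000 nM, which means an expected step of a 1.1-fold lower number from compound 2 to compound 3 (0.04 log units; within the scatter).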

Compound 3, half-maximal inhibitory concentration: 4560 nM
Compound 3: middle estimate off by 1.6-fold (0.22 log units), on the high side; the range from low to high includes it.
By their numbers in this assay, from the lowest: compounds 1, 3 and 2 (each within the scatter of the next, the first and the last beyond it).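

In this assay, acetamido in place of hydrogen on an aromatic carbon, para to a large group, gives a 1.8-fold lower number from compound 2 to compound 3 (0.26 log units; within the scatter), so this single change does not separate compound 3 from compound 2. For the compounds shown here, the phenyl on the sulfonyl group can therefore become 4-acetamidophenyl without a step beyond the scatter, which the earlier compounds could not show. Nothing available here accounts for the size of this step.

Going by these compounds, whether an amine, a carboxylic acid or a longer chain at the same place would also stay within the scatter remains open. This reading also rests on one pair, so it leaves open whether acetamido would give a similar step elsewhere on the ring or on the core of compound 1.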